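This account rests on a few compounds, and the source may have more. Where it says the series, first, only, none or still open, it means among the compounds named here.

In a functional assay on SW480 cells (Homo sapiens) for cytotoxicity, read by MTT assay, with a stated time of 24 h (a lower number here means a stronger inhibitor, a higher number a weaker inhibitor), compound 1 `C=CC1=C(C(=O)O)C(c2ccc(OC)cc2)OC1` gives > 100000 nM, which is a limit of the assay rather than a number. Compound 2 `C=CC1=C(C(=O)NCC(C)C)C(c2ccc(OC)cc2)OC1` gives > 100000 nM in this assay, again a limit. The step that the two limits leave unreadable from compound 1 to compound 2 is accordingly not readable; both points sit at the limit of > 100000 nM in this assay, at which 2 of the 2 values shown sit. Compound 2 thus stands only at a limit, with no numerical value on record.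

Compound 3 `C=CC1=C(C(=O)Nc2ccc(C)cc2)C(c2ccc(OC)cc2)OC1` differs from compound 2 by 4-methylphenyl in place of isobutyl on an amide-type nitrogen. Among the measured compounds shown here, no measured step bears directly on this change, and the single step available, a step that the two limits leave unreadable from compound 1 to compound 2, cannot be sized, so the series itself gives neither a direction nor a magnitude. For compound 3 the expectation is that it also remains at the limit, with the estimated step of a number no higher from compound 2 to compound 3 (the limit leaves the size open) not exceeding the usual scatter. Compound 3 is therefore estimated at 100000 nM, with a range from 30000 nM to 300000 nM in this assay.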

Compound 3, half-maximal inhibitory concentration: > 100000 nM
Compound 3: no number, only a limit; the forecaster's own chance of this, stated with the estimate: 80%; the middle value sits exactly at the limit.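

In this assay compound 3 gives > 100000 nM as a limit, not a number. Among the compounds shown here, no step among compound 1, compound 2 and compound 3 can be read: the limit of > 100000 nM in this assay, at which 3 of the 3 values shown sit. On these data alone, whether any of these changes on the carbonyl carbon or amide-type nitrogen shifts cytotoxicity stays open.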